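Aryl ether variation in the thromboxane synthase series

The source may hold more compounds than are shown below. What is called first, only, known or untested is meant among the compounds shown, and "the series" means these compounds.

Compound 1 `N#Cc1ccc(C2OCC(C/C=C\CCC(=O)O)C(c3cccnc3)O2)cc1` gives 24 nM in an assay for inhibition of Thromboxane-A synthase (Homo sapiens), using microsomes; a lower number here means a stronger inhibitor, a higher number a weaker inhibitor. Compound 2 `CC(C)(Oc1ccccc1)C1OCC(C/C=C\CCC(=O)O)C(c2cccnc2)O1` gives 52 nM in this assay, the step being a 2.2-fold higher number from compound 1 to compound 2 (0.34 log units; beyond the scatter). Compound 3 `Cc1ccc(C#N)c(OC(C)(C)C2OCC(C/C=C\CCC(=O)O)C(c3cccnc3)O2)c1` gives 50 nM in this assay, and the step to it is a 1.0-fold lower number from compound 2 to compound 3 (0.02 log units; within the scatter). Among the three measured compounds, compound 3 therefore holds the second highest number: it sits within the scatter of compound 2 and beyond the scatter above compound 1.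

Compound 4 `CC(C)(C)c1ccc(OC(C)(C)C2OCC(C/C=C\CCC(=O)O)C(c3cccnc3)O2)cc1` is not yet measured. The change from compound 3 is 4-(tert-butyl)phenyl in place of 2-cyano-5-methylphenyl on an oxygen on a saturated carbon. The step that bears most directly on it, the swap of the aryl group on the ether oxygen, was a 1.0-fold lower number from compound 2 to compound 3 (0.02 log units; within the scatter), and the larger replacement of the aryl group on the saturated ring carbon gave only a 2.2-fold higher number from compound 1 to compound 2 (0.34 log units; beyond the scatter). On that basis no step beyond the scatter is expected in this assay. Compound 4 is expected to give 50 nM, with a range of 20 nM to 130 nM. The expected step is no change at the digits printed from compound 3 to compound 4 (within the scatter).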

Compound 4, half-maximal inhibitory concentration: 280 nM
Estimate against measurement, compound 4: 5.6-fold (0.75 log units) below, and the stated range ends below it.
By their numbers in this assay, from the lowest: compound 1; then compounds 3 and 2 (each within the scatter of the next); then compound 4.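

On the oxygen on a saturated carbon, the aryl group matters more in this assay than the earlier aryl change suggested: 4-(tert-butyl)phenyl in place of 2-cyano-5-methylphenyl gives a 5.6-fold higher number from compound 3 to compound 4 (0.75 log units; beyond the scatter) while that earlier change stayed within the scatter. On the plain phenyl, tert-butyl in place of hydrogen on an aromatic carbon gives a 5.4-fold higher number from compound 2 to compound 4 (0.73 log units; beyond the scatter) and so this one added group is enough to carry the number beyond the scatter. Nothing available explains this step.

From the compounds shown here alone, it remains open whether a methoxy group or a chlorine atom in place of the tert-butyl group would stay within the scatter of compound 2 or rise towards compound 4. Also open, going by these compounds, is whether an isopropyl group, as a smaller branched carbon group, would give part of the step.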